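The compounds below may be only part of what the source reports. "The series", "measured", "known", "first", "only" and "open" are said of these compounds alone.

Compound 1 `Cc1cn(C2CCN(Cc3cccc(Oc4ccccc4)n3)CC2)c(=O)[nH]c1=O` is reported in an ADME assay on MRC5 cells (Homo sapiens) for cytotoxicity, read by fluorescence and resazurin assay, with a stated time of 3 days (a lower number here means a stronger inhibitor, a higher number a weaker inhibitor), only as the limit > 64000 nM. Compound 2 `Cc1cn(C2CCN(Cc3cccc(Oc4cccc(F)c4)c3)CC2)c(=O)[nH]c1=O` likewise reaches only the limit > 64000 nM in this assay. Compound 3 `Cc1cn(C2CCN(Cc3ccnc(Oc4cccc(Cl)c4)c3)CC2)c(=O)[nH]c1=O` also stops at the limit > 64000 nM in this assay.

Compound 2 therefore stands where every measured compound stands: at the ceiling of the measurement, as the limit of > 64000 nM in this assay, at which 3 of the 3 values shown sit, shows, with no number below it for any of them. Compound 4 `COc1ccc(Oc2cccc(CN3CCC(n4cc(C)c(=O)[nH]c4=O)CC3)c2)cc1` differs from compound 2 by 4-methoxyphenyl in place of 3-fluorophenyl on an oxygen on an aromatic ring.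

Within the data shown here, no measured step exists, so the size of the change is estimated rather than known; with all three values sitting at the limit, the expected step from compound 2 to compound 4 in this assay is a step that the limit leaves unreadable from compound 2 to compound 4, none beyond the scatter. Compound 4 is expected at 80000 nM, between 30000 nM and 250000 nM.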

Compound 4, half-maximal inhibitory concentration: 28000 nM
For compound 4 the middle estimate is 2.9-fold (0.46 log units) above the measured one, outside the stated range (below it).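

In this assay, among these compounds, putting 4-methoxyphenyl in place of 3-fluorophenyl on the oxygen gives an at least 2.2-fold lower number from compound 2 to compound 4 (0.35 log units; beyond the scatter), and compound 4 is the first compound here with a real number. The group on this oxygen can therefore move the reading off the limit of the assay. Compound 2 has only a limit, so the true step may be larger: the limit of > 64000 nM in this assay, at which 3 of the 4 values shown sit.

The change swaps the fluorine and adds the methoxy group in one move, so the compounds shown cannot separate the two. From the compounds shown here alone, how a phenyl ring carrying an amine or a carboxylic acid would read here also stays open.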